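The source may hold more compounds than are shown below. What is called first, only, known or untested is meant among the compounds shown, and "the series" means these compounds.

Measured compounds:
compound 1, `O=C(NC/C=C1\CCCc2cnn(-c3ccc(C(F)(F)F)cc3)c21)NS(=O)(=O)c1cc(Cl)c(Cl)s1`, 4 nM
compound 2, `Cc1nc(C)c(S(=O)(=O)NC(=O)NC/C=C2\CCCc3cnn(Cc4ccc(Cl)cc4Cl)c32)s1`, 4 nM
compound 3, `O=C(NC/C(F)=C1\CCCc2cnn(Cc3ccc(C(F)(F)F)cc3)c21)NS(=O)(=O)c1cc(Cl)c(Cl)s1`, 52 nM

These three compounds were tested in a functional assay on CHO-K1 cells for antagonist activity at prostaglandin E2 receptor EP3 subtype (Homo sapiens), read by TR-FRET and cAMP accumulation, with a stated time of 30 min; a lower number here means a stronger inhibitor, a higher number a weaker inhibitor. Compound 2 gives 4 nM, level with compound 1 at the digits shown, and the two together stand lowest of the three numbers. Compound 3 gives 52 nM, a higher number than compound 2, and that gap lies beyond the usual scatter of this assay. Compound 1 and compound 2 carry different groups on the sulfonyl sulfur yet give the same number, which suggests that this position tolerates some variation.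

Compound 4, `Cn1cc(S(=O)(=O)NC(=O)NC/C=C2\CCCc3cnn(Cc4ccc(Cl)cc4Cl)c32)cn1`, has not yet been measured. It differs from compound 2 in one place: 1-methyl-1H-pyrazol-4-yl in place of 2,4-dimethyl-1,3-thiazol-5-yl on a sulfonyl sulfur. For the measured compounds named here, no measured pair shows this particular change, so its effect has to be guessed. Because compound 1 gives 4 nM and compound 2 gives 4 nM with different groups on the sulfonyl sulfur, a small weakening is expected, a 3.0-fold higher number from compound 2 to compound 4 (0.48 log units; beyond the scatter), most likely within or just beyond the scatter. Compound 4 is therefore estimated at 12 nM in this assay, with a plausible range from 3 nM to 50 nM.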

Compound 4, half-maximal inhibitory concentration: 8 nM
Compound 4: the middle estimate sits 1.5-fold (0.18 log units) above what was measured; the range from low to high includes it.
By their numbers in this assay, from the lowest: compounds 1, 2 and 4 (each within the scatter of the next); then compound 3.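

For the compounds shown here, replacing 2,4-dimethyl-1,3-thiazol-5-yl with 1-methyl-1H-pyrazol-4-yl on the sulfonyl sulfur gives a 2.0-fold higher number from compound 2 to compound 4 (0.30 log units; within the scatter) in this assay and is the first change at this position that can be read on its own, with the rest of the molecule held constant. The pair shows that the five-membered aromatic ring on the sulfonyl sulfur can trade its sulfur atom for a second nitrogen while the two numbers stay within the usual scatter of each other. Nothing given here offers a reason for this result.

As far as these compounds go, both rings are five-membered and aromatic, so it remains open how a six-membered pyridine ring or a plain methyl group on the sulfonyl sulfur would read. Also open, from the compounds shown here alone, is what the methyl group on the pyrazole contributes, which a pyrazole carrying hydrogen in its place would test.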